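Butyl in Place of Cyclopentyl on an Aromatic Nitrogen

The compounds below may be only part of what the source reports. "The series", "measured", "known", "first", "only" and "open" are said of these compounds alone.

Among the measured compounds shown here, in a functional assay on RAW264.7 cells (Mus musculus) for inhibition, read by Griess assay, with stated times of 2 h and 24 h (on this read-out lower numbers stand for stronger inhibition and higher numbers for weaker inhibition), compound 1 `COc1ccc([C@@H]2CC(=O)c3c(O)cc(OCc4cn(C5CCCC5)nn4)cc3O2)cc1O` gives 10500 nM, the lowest of the three numbers measured so far. Compound 2 `COc1ccc([C@@H]2CC(=O)c3c(O)cc(OCc4cn(Cc5cccc(Cl)c5)nn4)cc3O2)cc1O` gives 18200 nM and compound 3 `COc1ccc([C@@H]2CC(=O)c3c(O)cc(OCc4cn(Cc5ccc(C)cc5)nn4)cc3O2)cc1O` gives 16800 nM. Neither step away from compound 1 leaves the scatter: a 1.7-fold higher number from compound 1 to compound 2 (0.24 log units; within the scatter) and a 1.6-fold higher number from compound 1 to compound 3 (0.20 log units; within the scatter), and the pair of benzyl groups differs just as little, a 1.1-fold lower number from compound 2 to compound 3 (0.03 log units; within the scatter). Compound 4 `CCCCn1cc(COc2cc(O)c3c(c2)O[C@H](c2ccc(OC)c(O)c2)CC3=O)nn1` differs from compound 1 in one place: butyl in place of cyclopentyl on an aromatic nitrogen. The two measured replacements of cyclopentyl on the same aromatic nitrogen bear on this change, and because a 1.7-fold higher number from compound 1 to compound 2 (0.24 log units; within the scatter) and a 1.6-fold higher number from compound 1 to compound 3 (0.20 log units; within the scatter) both stayed within the scatter, no step beyond the scatter is expected here either. Compound 4 is therefore estimated at 11000 nM, between 5000 nM and 25000 nM, which is expected to mean a 1.0-fold higher number from compound 1 to compound 4 (0.02 log units; within the scatter).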

Compound 4, half-maximal inhibitory concentration: 13900 nM
Compound 4: middle estimate off by 1.3-fold (0.10 log units), on the low side, within the range that was stated.
By their numbers in this assay, from the lowest: compounds 1, 4, 3 and 2 (each within the scatter of the next).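

In this assay, an open butyl chain on the aromatic nitrogen in place of the cyclopentyl ring gives a 1.3-fold higher number from compound 1 to compound 4 (0.12 log units; within the scatter), so a group with no ring also stays within the scatter at this position. The same holds against the two benzyl groups, with a 1.2-fold lower number from compound 3 to compound 4 (0.08 log units; within the scatter) and a 1.3-fold lower number from compound 2 to compound 4 (0.12 log units; within the scatter), so all four groups shown here lie within the scatter of one another. No measurement offered here explains this result. The compounds shown leave open whether an amine or a carboxylic acid on this nitrogen, or a longer chain such as octyl, would move the number beyond the scatter.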